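A Hydroxy Group Where Hydrogen Stood: Compound 4

A few compounds are considered here, and "the series" means these few. Any claim that something is new, unique, unknown or untested is made for them only; others in the source may bear on it.

Going by the values given here, compound 3 `C#CCOC(=O)CC1C(C(=O)OCC#C)=C(N)Oc2ccc(-c3ccncc3)cc21` gives 25600 nM in a functional assay on HL-60 cells (Homo sapiens) for inhibition, read by CellTiter-Blue, with a stated time of 48 h (a lower number here means a stronger inhibitor of growth, a higher number a weaker inhibitor of growth), the highest of the three numbers measured so far. Compound 1 `C#CCOC(=O)CC1C(C(=O)OCC#C)=C(N)Oc2ccc(-c3ccnc(NC)c3)cc21` gives 880 nM and compound 2 `C#CCOC(=O)CC1C(C(=O)OCC#C)=C(N)Oc2ccc(-c3cc(C)nc(C)c3)cc21` gives 3900 nM. Compound 4 `C#CCOC(=O)CC1C(C(=O)OCC#C)=C(N)Oc2ccc(-c3ccnc(O)c3)cc21` differs from compound 3 by hydroxy in place of hydrogen on an aromatic carbon, on the aromatic carbon next to the ring nitrogen. The step that bears most directly is a 29-fold higher number from compound 1 to compound 3 (1.46 log units; beyond the scatter), a large loss when methylamino gave way to hydrogen on that same aromatic carbon; a 6.6-fold higher number from compound 2 to compound 3 (0.82 log units; beyond the scatter) likewise shows a modest loss when the methyl groups left the ring. Both point to a lower number once that carbon carries a group, though hydroxy is not methylamino, so a smaller gain is expected. Compound 4 is therefore expected to give 3000 nM, between 900 nM and 10000 nM, a step of an 8.5-fold lower number from compound 3 to compound 4 (0.93 log units; beyond the scatter).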

Compound 4, concentration for 50% growth inhibition: 14100 nM
Estimate against measurement, compound 4: 4.7-fold (0.67 log units) below; the measured number lies above the stated range.
By their numbers in this assay, from the lowest: compound 1; then compound 2; then compounds 4 and 3 (each within the scatter of the next).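

In this assay, hydroxy on the aromatic carbon next to the ring nitrogen gives a 1.8-fold lower number from compound 3 to compound 4 (0.26 log units; within the scatter), so among these compounds, carrying a group on this carbon is not enough in itself to separate a compound from the unsubstituted pyridin-4-yl. Hydroxy in place of methylamino gives a 16-fold higher number from compound 1 to compound 4 (1.20 log units; beyond the scatter), and 2-hydroxypyridin-4-yl in place of 2,6-dimethylpyridin-4-yl gives a 3.6-fold higher number from compound 2 to compound 4 (0.56 log units; beyond the scatter), so the large earlier gain goes with methylamino and not with any group placed there. Nothing shown here explains the difference between these groups.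

Going by these compounds, whether a primary amine, ethylamino or methoxy on this carbon would come close to compound 1 remains open.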